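A Methyl-to-Fluoro Swap Carried Onto a Second Core

The compounds below may be only part of what the source reports. "The series", "measured", "known", "first", "only" and "open" are said of these compounds alone.

The four compounds share most of their framework and differ in two respects: the aromatic ring that bears the amide, and a single group on the outer phenyl ring. Compound 1 `COc1cc2c(Oc3ccc(NC(=O)c4cc(-c5ccc(C)cc5)ccn4)cc3F)ccnc2cc1OCCCN1CCCC1` and compound 2 `COc1cc2c(Oc3ccc(NC(=O)c4cc(-c5ccc(F)cc5)ccn4)cc3F)ccnc2cc1OCCCN1CCCC1` make up the first pair, compound 3 `COc1cc2c(Oc3ccc(NC(=O)c4nccc(-c5ccc(C)cc5)n4)cc3F)ccnc2cc1OCCCN1CCCC1` and compound 4 `COc1cc2c(Oc3ccc(NC(=O)c4nccc(-c5ccc(F)cc5)n4)cc3F)ccnc2cc1OCCCN1CCCC1` the second. In a functional assay on NCI-H460 cells (Homo sapiens) for cytotoxicity, read by MTT assay, with a stated time of 72 h (a higher number here means a weaker inhibitor, a lower number a stronger inhibitor), compound 1 gives 160 nM, compound 2 gives 370 nM, and compound 3 gives 440 nM. Within the first pair, the change fluoro in place of methyl on an aromatic carbon produced a 2.3-fold higher number from compound 1 to compound 2 (0.36 log units; beyond the scatter). The difference between the core of compound 1 and the core of compound 3 is not broken down here. For the measured compounds named here, compound 4 carries the same change on the core of compound 3, (fluoro in place of methyl on an aromatic carbon), and the surroundings of the place are described in identical words, so the single earlier step is the only available guide. The analyst expects for compound 4 a step of a 2.3-fold higher number from compound 3 to compound 4 (0.36 log units; beyond the scatter) because the same change earlier gave a 2.3-fold higher number from compound 1 to compound 2 (0.36 log units; beyond the scatter). Resting on one instance, the estimate is kept wide. Compound 4 is estimated at 1000 nM in this assay, between 500 nM and 2100 nM.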

Compound 4, half-maximal inhibitory concentration: 300 nM
Compound 4: middle estimate off by 3.3-fold (0.52 log units), on the high side; measured number outside the range, below it.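

On the core of compound 3, replacing 4-methylphenyl with 4-fluorophenyl gives a 1.5-fold lower number from compound 3 to compound 4 (0.17 log units; within the scatter) in this assay, so this pair shows no separation in this cell read-out. The change therefore did not carry its earlier size over from one core to the other, and the step seen on the core of compound 1 did not reappear on the core of compound 3: the same change on two cores in this assay, a 2.3-fold higher number (0.36 log units; beyond the scatter) from compound 1 to compound 2 and a 1.5-fold lower number (0.17 log units; within the scatter) from compound 3 to compound 4, 3.4-fold (0.53 log units) apart, beyond the scatter of two such steps

For the compounds shown here, with only one step on each core, and the second lying within the scatter, this does not establish that the change reverses direction on the second core, nor does it identify what in the two cores sets the steps apart.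

The compounds shown leave open whether other groups at the same place, such as chloro, methoxy, trifluoromethyl or an amine, would respond to the core as methyl and fluoro do here. They also leave open how the 4-methylphenyl to 4-fluorophenyl change would behave on any third core.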